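A Fourth Amide Alongside Three Measured Compounds

The source may report more compounds than this note shows. Statements on the series, on what has been measured and on what is new or still open speak of the compounds shown alone.

The shared core carries a side chain ending in a carbonyl group, and the three measured compounds differ only in what sits on that carbonyl carbon. Compound 1 `COc1cc2c(cc1OC)C(CC(=O)O)CC2` bears a hydroxy group there; in a functional assay on the whole organism (strain Wistar) for inhibition, with Rattus norvegicus as the target, read by paw edema, with a stated time of 2 h, at a dose of 100 mg/kg (on this read-out lower numbers stand for less inhibition and higher numbers for more inhibition at the one dose given (going by the name of the read-out)), compound 1 gives 24%. Compound 2 `COc1cc2c(cc1OC)C(CC(=O)Nc1ccccc1)CC2` bears an anilino group instead, and in this assay compound 2 gives 32%, which is a number 8 percentage points higher from compound 1 to compound 2 (within the scatter). Compound 3 `COc1cc2c(cc1OC)C(CC(=O)Nc1ccc(Br)cc1)CC2` carries a (4-bromophenyl)amino group; in this assay compound 3 gives 40%. That is a number 16 percentage points higher from compound 1 to compound 3 (beyond the scatter) and a number 8 percentage points higher from compound 2 to compound 3 (within the scatter). So compound 3 shows the highest of the three numbers, clearly separated from compound 1 but not from compound 2.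

Compound 4 `COc1cc2c(cc1OC)C(CC(=O)Nc1ccc([N+](=O)[O-])cc1)CC2` differs from compound 3 in one place: nitro in place of bromo on an aromatic carbon. Going by the values given here, no measured step exchanges one group on that aromatic carbon for another; the only nearby step, from hydrogen to bromo, stayed within the scatter. A small step is therefore expected in this assay, with no clear direction, namely no change at the digits printed from compound 3 to compound 4 (within the scatter). For compound 4 the estimated value in this assay is 40%, within a range from 28% to 52%.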

Compound 4, a percentage reported as inhibition, in the whole organism at one dose (the size of the read-out at that dose, not a potency): 36%
The estimate for compound 4 lay 4 percentage points above the measured number; the measured number falls inside the stated range.
By their numbers in this assay, from the lowest: compounds 1, 2, 4 and 3 (each within the scatter of the next, the first and the last beyond it).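

In this assay, going by these compounds alone, this is the first direct exchange of one group for another on this aromatic carbon, and nitro in place of bromo gives a number 4 percentage points lower from compound 3 to compound 4 (within the scatter) here. Nitro in place of hydrogen gives a number 4 percentage points higher from compound 2 to compound 4 (within the scatter) at the same place, so neither this step nor the earlier step from hydrogen to bromo separates the compounds beyond the usual scatter. Nothing available explains these numbers or links them to any property of the groups.

On these data alone, whether a methoxy group, an amino group or a carboxylic acid on this aromatic carbon would give a number beyond the scatter remains open. Also open, as far as these compounds go, is whether a nitro or bromo group on another carbon of the same ring would read any differently at this single dose and time.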